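The source may hold more compounds than are shown below. What is called first, only, known or untested is meant among the compounds shown, and "the series" means these compounds.

Working notes on the series. In a functional assay on A-375 cells (Homo sapiens) for antiproliferative activity (on this read-out higher numbers stand for weaker inhibition and lower numbers for stronger inhibition), compound 1 (`O=C(Nc1ccc(-c2cscn2)cc1)C1CCN(Cc2ccc(F)c(F)c2)C1`) gives 10000 nM. Compound 2 (`O=C(Nc1ccc(-c2cscn2)cc1)C1CCCN(C(=O)c2ccc(F)c(F)c2)C1`) stands at > 20000 nM, which is a limit and not a number. Compound 3 (`O=C(Nc1ccc(-c2cscn2)cc1)C1CCCN(Cc2cccc(F)c2F)C1`) has not yet been measured. It carries 2,3-difluorobenzyl in place of the (3,4-difluorophenyl)carbonyl of compound 2, on an amine nitrogen in a ring: 2,3-difluorobenzyl in place of (3,4-difluorophenyl)carbonyl on an amine nitrogen in a ring. Going by the values given here, no measured step isolates this change, so any expectation rests on little. Among the compounds with values here, a modest move towards stronger inhibition in this assay is expected, since compound 1, the only measured compound with a benzyl group on its ring nitrogen, gives 10000 nM. The estimated step is an at least 1.6-fold lower number from compound 2 to compound 3 (0.22 log units; that floor lies within the scatter). For compound 3 the expected value is 12000 nM, with an estimated range of 4000 nM to 30000 nM.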

Compound 3, half-maximal inhibitory concentration: 1480 nM
Compound 3: middle estimate off by 8.1-fold (0.91 log units), on the high side, and the stated range ends above it.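

In this assay, 2,3-difluorobenzyl in place of (3,4-difluorophenyl)carbonyl on the amine nitrogen of the six-membered non-aromatic ring gives an at least 13-fold lower number from compound 2 to compound 3 (1.13 log units; beyond the scatter), so the group on this nitrogen strongly affects the read-out. Compound 3 also shows that a measurable value can be reached with this six-membered ring, which compound 2 did not show. The value of compound 2 is a limit, and the step is only a floor because of it: the limit of > 20000 nM in this assay, at which 1 of the 3 values shown sits.

The change alters both the link to the nitrogen and the fluorine pattern at once, and the compounds shown do not separate these two effects. As far as these compounds go, whether an unsubstituted benzyl or a longer chain such as 2-phenylethyl on this nitrogen would match compound 3 also stays open.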